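Trading Trifluoromethyl for Fluoro in Compound 1

This account rests on a few compounds, and the source may have more. Where it says the series, first, only, none or still open, it means among the compounds named here.

Measured so far:
- compound 1 `FC(F)(F)c1ccccc1Nc1nc(-c2ccncc2)cs1`: 40700 nM
- compound 2 `Cc1cccc(Nc2cccc(-c3ccncc3)c2)c1`: 36900 nM; 37200 nM (2 entries)
- compound 3 `COc1ccc(Nc2nc(-c3ccncc3)cs2)cc1OC`: 24500 nM

Of the compounds shown here, three have been tested in a functional assay on RCC4 cells (Homo sapiens) for inhibition, read by XTT assay, with a stated time of 4 days; a lower number here means a stronger inhibitor, a higher number a weaker inhibitor. Compound 1 gives 40700 nM, compound 3 gives 24500 nM, and the two numbers lie within the usual scatter of each other, so neither can be called the stronger inhibitor. Compound 2 has been run more than once, and its entries (the several entries of compound 2 in this assay, 36900 nM; 37200 nM (2 entries)) agree closely and sit in the same weak range. All three, then, inhibit the cells only at high concentrations.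

Compound 4 `Fc1ccccc1Nc1nc(-c2ccncc2)cs1` is the next compound, still to be measured in this assay. It differs from compound 1 in one place: fluoro in place of trifluoromethyl on an aromatic carbon. The rest of the molecule is unchanged.

Among the compounds with values here, no measured pair in this set isolates this change, so the expectation for compound 4 rests on the narrow band the three measured compounds occupy. The step from a 1.2-fold lower number from compound 1 to compound 4 (0.07 log units; within the scatter) is expected to stay within the scatter. Compound 4 is therefore estimated at 35000 nM, with a range from 12000 nM to 100000 nM.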

Compound 4, half-maximal inhibitory concentration: 14500 nM
Compound 4: middle estimate off by 2.4-fold (0.38 log units), on the high side; low and high end bracket the measured number.
By their numbers in this assay, from the lowest: compounds 4, 3 and 1 (each within the scatter of the next, the first and the last beyond it).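

On this aromatic carbon, ortho to a large group, the choice of substituent matters in this assay: fluoro in place of trifluoromethyl brings a 2.8-fold lower number from compound 1 to compound 4 (0.45 log units; beyond the scatter). Within the data shown here, this is the first step between two compounds that differ in one place, and it shows that the narrow band of the earlier numbers did not mean that this position has no effect on the read-out. The step is modest, but repeat entries in this assay agree closely, which lends it weight: the several entries of compound 2 in this assay, 36900 nM; 37200 nM (2 entries)

On these data alone, how a chloro, a methyl or an amine on the same carbon would compare remains open, so a single step cannot show what in the change produces the lower number. Also open, as far as these compounds go, is whether any change at this position can take the series far beyond compound 4, which still gives 14500 nM.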